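Moving two fluorines on the side chain

A few compounds are considered here, and "the series" means these few. Any claim that something is new, unique, unknown or untested is made for them only; others in the source may bear on it.

In a toxicity assay on MT2 cells (Homo sapiens) for cytotoxicity, read by XTT assay, with a stated time of 4 days (on this read-out lower numbers stand for higher toxicity in this test and higher numbers for lower toxicity in this test), compound 1 (`COc1ccc(CCOc2ccc(-c3c(C)nc(C)c([C@H](OC(C)(C)C)C(=O)O)c3N3CCC(C)(C)CC3)cc2)cc1`) gives >= 33500 nM, which is a limit and not a number. Compound 2 (`Cc1nc(C)c([C@H](OC(C)(C)C)C(=O)O)c(N2CCC(C)(C)CC2)c1-c1ccc(OCCc2cc(F)ccc2F)cc1`) gives >= 33500 nM, also a limit. Both stand at the limit of >= 33500 nM in this assay, at which 2 of the 2 values shown sit. Going by the values given here, the only measured change here is a step that the two limits leave unreadable from compound 1 to compound 2, with 2,5-difluorophenyl in place of 4-methoxyphenyl. Compound 3 (`Cc1nc(C)c([C@H](OC(C)(C)C)C(=O)O)c(N2CCC(C)(C)CC2)c1-c1ccc(OCCc2ccc(F)c(F)c2)cc1`) has 3,4-difluorophenyl in place of 2,5-difluorophenyl on a saturated chain carbon, two bonds along the chain from an oxygen on an aromatic ring. That measured step offers no size to carry over, so no change beyond the scatter is expected. The expected step is a number no higher from compound 2 to compound 3 (the limit leaves the size open). For compound 3 the estimate is 33500 nM, with an expected range of 15000 nM to 70000 nM.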

Compound 3, half-maximal cytotoxic concentration: >= 33500 nM
Compound 3 was reported as a limit; the forecaster's own chance of this, stated with the estimate: 80%; the middle value lies on the limit itself.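

Compound 3 is also reported only as a limit, so no step can be read among compound 1, compound 2 and compound 3: the limit of >= 33500 nM in this assay, at which 3 of the 3 values shown sit. On these data alone, whether 2,5-difluorophenyl and 3,4-difluorophenyl differ at all in this assay stays open.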